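Toward Compound 3: Tolerance in a Cell-Damage Test

A few compounds are considered here, and "the series" means these few. Any claim that something is new, unique, unknown or untested is made for them only; others in the source may bear on it.

Compound 1 `CCOC(=O)C1(Cc2ccccc2)CN(c2ccccc2)Cc2nnn(Cc3ccc(OC)cc3)c21` was examined in an ADME assay on HEL cells (Homo sapiens) for cytotoxicity, read by microscopy, with a stated time of 3 days; a higher number here means that more compound is tolerated, a lower number that less compound is tolerated. In this assay compound 1 gives > 100000 nM, which is a limit of the assay and not a measured number. A close relative, compound 2 `CCOC(=O)C1(Cc2ccccc2)CN(c2ccccc2)Cc2nnn(Cc3cccc(F)c3)c21`, was examined in the same way; in this assay compound 2 gives >= 100000 nM, again a limit. Comparing the two yields a step that the two limits leave unreadable from compound 1 to compound 2, so the swap of the benzyl group tells nothing about size or direction, simply because both values rest at the limits the limit of > 100000 nM in this assay, at which 1 of the 2 values shown sits, and (the limit of >= 100000 nM in this assay, at which 1 of the 2 values shown sits).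

Compound 3 `CCOC(=O)C1(Cc2ccccc2)CN(c2ccccc2)Cc2nnn(Cc3cccc(Cl)c3)c21` is not yet measured. It differs from compound 1 in one place: 3-chlorophenyl in place of 4-methoxyphenyl on a saturated chain carbon bound to an aromatic nitrogen. Within the data shown here, the only measured comparison that bears on this kind of change is the one from compound 1 to compound 2, and it is unreadable. With compound 1 already sitting at a limit, no step beyond the usual scatter is expected in either direction. Compound 3 is therefore expected to give about 100000 nM in this assay, within a range from 50000 nM to 200000 nM. This estimate corresponds to an expected step of a number no higher from compound 1 to compound 3 (the limit leaves the size open).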

Compound 3, minimum cytotoxic concentration: > 100000 nM
Compound 3 ended at the assay's limit (the forecaster's own chance of this, stated with the estimate: 80%); the middle value lies on the limit itself.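

In this assay, the steps from compound 1 to compound 3 and from compound 2 to compound 3 cannot be read, because these values are limits of the assay and not measured numbers: the limit of > 100000 nM in this assay, at which 2 of the 3 values shown sit. Compound 2 rests at a limit too: the limit of >= 100000 nM in this assay, at which 1 of the 3 values shown sits. The compounds shown leave open how much of each compound is tolerated past these limits, and whether swapping the benzyl groups changes it at all.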